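The source may report more compounds than this note shows. Statements on the series, on what has been measured and on what is new or still open speak of the compounds shown alone.

In an ADME assay on MT4 cells (Homo sapiens) for cytotoxicity, read by MTT assay, with a stated time of 5 days (a lower number here means that less compound is tolerated, a higher number that more compound is tolerated), compound 1 `COc1cc2cc(C#N)ccc2c(OC)c1Oc1cc(NC2CC2)nc(Nc2ccc(C#N)cc2)n1` gives > 125000 nM as a limit of the assay and not a number. Compound 2 `COc1cc2cc(C#N)ccc2c(OC)c1Oc1cc(NC2CCCC2)nc(Nc2ccc(C#N)cc2)n1` likewise gives > 125000 nM as a limit, so it has no number of its own. For the measured compounds named here, the one measured step that bears on what follows is a step that the two limits leave unreadable from compound 1 to compound 2 and it put cyclopentyl in place of cyclopropyl on a nitrogen on an aromatic ring. Compound 3 `COc1cc2cc(C#N)ccc2c(OC)c1Oc1cc(NC2CCCCC2)nc(Nc2ccc(C#N)cc2)n1` carries cyclohexyl in place of cyclopentyl at that same place, counted as cyclohexyl in place of cyclopentyl on a nitrogen on an aromatic ring for this change. Going by the values given here, for compound 2 the only guide is the limit of > 125000 nM in this assay, at which 2 of the 2 values shown sit, and so no change beyond the scatter, in either direction, is expected in this assay for this change. The expected step is a number no higher from compound 2 to compound 3 (the limit leaves the size open) in this estimate. For compound 3 the estimated value is 125000 nM with an expected range from 60000 nM to 250000 nM and a report as a limit is expected to be the likeliest outcome.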

Compound 3, half-maximal cytotoxic concentration: > 125000 nM
Compound 3: a limit, no number (the forecaster's own chance of this, stated with the estimate: 80%); the middle value lies on the limit itself.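

Compound 3 is reported only as a limit, as are compound 1 and compound 2, so no step among these three compounds can be read in this assay. The compounds shown leave open how much of each compound is tolerated, and whether the cycloalkyl groups differ at all.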